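Bromo replacing methoxymethyl on a shared two-ring core

The compounds below may be only part of what the source reports. "The series", "measured", "known", "first", "only" and "open" are said of these compounds alone.

Compound 1 `Cc1nc2c(OCc3ccccc3)cccn2c1C#N` gives 4% in a functional assay on the whole organism (stomach) for inhibition, with Canis familiaris (Canis lupus familiaris) as the target, at a dose of 5 mg/kg by the intravenous route; on this read-out lower numbers stand for a weaker effect and higher numbers for a stronger effect at the one dose given.
Compound 2 `Cc1nc2c(OCc3ccccc3)cccn2c1CCC#N` gives 20% in this assay.
Compound 3 `COCc1c(C)nc2c(OCc3ccccc3)cccn12` gives 29% in this assay.

Compound 3 has the highest number of the three, but its gap to compound 2 is within the scatter; only the difference to compound 1 stands out, as a number 25 percentage points higher from compound 1 to compound 3 (beyond the scatter) shows. Compound 4 `Cc1nc2c(OCc3ccccc3)cccn2c1Br` is not yet measured; it differs from compound 3 as follows: bromo in place of methoxymethyl on an aromatic carbon. Within the data shown here, no measured step involves bromo. The steps of a number 16 percentage points higher from compound 1 to compound 2 (beyond the scatter) and a number 25 percentage points higher from compound 1 to compound 3 (beyond the scatter) show that changing the group at this place shifts the read-out modestly, and that the smallest group, in compound 1, gave the lowest number. Bromo is also a single-atom group, so a modest downward step a number 14 percentage points lower from compound 3 to compound 4 (beyond the scatter) is expected. Compound 4 is therefore estimated at 15%, within a range from 0% to 38%.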

Compound 4, a percentage reported as inhibition, in the whole organism at one dose (the size of the read-out at that dose, not a potency): 63%
For compound 4 the middle estimate is 48 percentage points below the measured one; measured number above the stated range.
By their numbers in this assay, from the lowest: compound 1; then compounds 2 and 3 (each within the scatter of the next); then compound 4.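

Bromo on this aromatic carbon stands clear of every earlier group in this assay, with large steps against methoxymethyl (a number 34 percentage points higher from compound 3 to compound 4 (beyond the scatter)), 2-cyanoethyl (a number 43 percentage points higher from compound 2 to compound 4 (beyond the scatter)) and cyano (a number 59 percentage points higher from compound 1 to compound 4 (beyond the scatter)). The single heavy atom of bromo thus goes with the highest number of the four, so a group with few heavy atoms at this place need not give a low number. Nothing available here explains this jump.

From the compounds shown here alone, it remains open whether chloro, iodo, an amine or a carboxylic acid at this place would match bromo. Going by these compounds, it is also open whether the gain holds at other doses.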